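Cyclopropyl to Isopropyl: Expected Effect on Growth Inhibition

The compounds below may be only part of what the source reports. "The series", "measured", "known", "first", "only" and "open" are said of these compounds alone.

Measured compounds:
compound 1 `COC(=O)C#CC(O/C=C/C(=O)OC)C(C)c1ccccc1` — 1200 nM
compound 2 `COC(=O)C#CC(O/C=C/C(=O)OC)C1CC1` — 1800 nM
compound 3 `C#CCO/C=C/C(=O)OC` — > 100000 nM

In a functional assay on SW1573 cells (Homo sapiens) for antiproliferative activity, read by sulforhodamine B assay, with a stated time of 48 h (on this read-out lower numbers stand for stronger inhibition of growth and higher numbers for weaker inhibition of growth), compound 1 gives 1200 nM and compound 2 gives 1800 nM. Compound 3 gives only > 100000 nM, which is a limit of the assay rather than a number. Compound 2 holds the higher of the two numbers, yet its gap to compound 1 lies within the scatter, so the two cannot be told apart. Compound 4 `COC(=O)C#CC(O/C=C/C(=O)OC)C(C)C` is not yet measured. It differs from compound 2 by isopropyl in place of cyclopropyl on a saturated chain carbon bound to an oxygen on an unsaturated carbon and a triple-bonded carbon. Within the data shown here, no measured pair shows this exchange, so no step beyond the scatter is expected in this assay. Compound 4 is therefore estimated at 2000 nM (range 900 nM to 5000 nM), an expected step of a 1.1-fold higher number from compound 2 to compound 4 (0.05 log units; within the scatter).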

Compound 4, concentration for 50% growth inhibition: 750 nM
Beside the measured number, compound 4's estimate is 2.7-fold (0.43 log units) above it; measured number below the stated range.
By their numbers in this assay, from the lowest: compounds 4, 1 and 2 (each within the scatter of the next, the first and the last beyond it). At a limit, above all of these: compound 3.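

In this assay, the carbon bound to the oxygen responds to the shape of its group: with the same count of heavy atoms, isopropyl in place of cyclopropyl gives a 2.4-fold lower number from compound 2 to compound 4 (0.38 log units; beyond the scatter), the first single-place step measured here. By contrast, methyl in place of phenyl on the branch gives a 1.6-fold lower number from compound 1 to compound 4 (0.20 log units; within the scatter), so that exchange shows no measurable difference. Nothing measured here explains why the open branch and the ring differ.

Going by these compounds, it remains open whether a tert-butyl group or a longer chain at this position would lower the number further. How an amine there would read is also unknown.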